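A few compounds are considered here, and "the series" means these few. Any claim that something is new, unique, unknown or untested is made for them only; others in the source may bear on it.

Working notes on the series.

Three compounds have been run in a functional assay on CHO cells for positive allosteric modulation of metabotropic glutamate receptor 2 (Homo sapiens), with a stated time of 30 min (on this read-out higher numbers stand for larger maximal responses and lower numbers for smaller maximal responses), so far. Compound 1 `CC(C)CCn1ccc(N2CCN(c3ccccn3)CC2)c(C#N)c1=O` gives 304%. Compound 2 `N#Cc1c(N2CCC(c3ccccc3)CC2)ccn(CC2CCC2)c1=O` gives 269% in this assay. Compound 3 `N#Cc1c(N2CCC(c3ccccc3F)CC2)ccn(CC2CC2)c1=O` gives 282% in this assay, which places it second highest of the three numbers: compound 2 sits nearest, lower by a margin beyond the scatter, and compound 1 sits furthest, higher by a margin beyond the scatter.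

The next compound to be run is compound 4 `N#Cc1c(N2CCC(c3c(F)cccc3F)CC2)ccn(CC2CC2)c1=O`. It differs from compound 3 in one place: fluoro in place of hydrogen on an aromatic carbon. Cut one bond further out, the change reads 2-fluorophenyl to 2,6-difluorophenyl.

Within the data shown here, no step between two measured compounds in this set isolates a change of this kind, so there is no measured step to lean on. The three numbers in this assay all lie within a fairly narrow band, and nothing in them points to a large move in either direction for a single added fluoro. The step from compound 3 to compound 4 is therefore expected to be small, a number 7 percentage points lower from compound 3 to compound 4 (within the scatter), most likely not beyond the scatter. For compound 4 the expected value in this assay is 275%, with a range from 230% to 320%.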

Compound 4, largest response reached (Emax), in percent of the reference or control that the assay uses: 291%
The estimate for compound 4 lay 16 percentage points below the measured number; low and high end bracket the measured number.
By their numbers in this assay, from the lowest: compound 2; then compounds 3 and 4 (each within the scatter of the next); then compound 1.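

In this assay, among these compounds, the change from 2-fluorophenyl to 2,6-difluorophenyl gives the first step that isolates a single place: a number 9 percentage points higher from compound 3 to compound 4 (within the scatter). Among the compounds shown here, this position, on an aromatic carbon ortho to a large group and meta to a fluoro group, therefore takes a fluoro in place of hydrogen with no step beyond the scatter on this read-out, something the earlier compounds, which differ in more than one place, could not show. No accompanying data bear on what lies behind this step, and it rests on a single pair of compounds.

Open, from the compounds shown here alone, is whether a chloro, a methoxy or an amine at this same position would also stay within the scatter of compound 3, or whether a group larger than fluoro would give a step beyond it. For the compounds shown here, also open is whether the same fluoro for hydrogen change would read alike with the side chain of compound 2 or of compound 1 in place of the one shared by compound 3 and compound 4.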